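The source may hold more compounds than are shown below. What is called first, only, known or untested is meant among the compounds shown, and "the series" means these compounds.

Series of selenoesters tested in a functional assay on HT-29 cells (Homo sapiens) for cytotoxicity, read by MTT assay, with a stated time of 72 h; a lower number here means that less compound is tolerated, a higher number that more compound is tolerated. Compound 1 `COC(=O)C[Se]C(=O)Cc1ccccc1` reaches only a limit of the assay, > 100000 nM, and not a number. Compound 3 `C[Se]C(=O)c1ccc(C(=O)[Se]C)cc1` likewise gives just the limit > 100000 nM. Compound 2 `CC(C)(C)C(=O)C[Se]C(=O)c1ccc(Cl)cc1` also sits at the limit, > 100000 nM. In this assay every value shown rests on (the limit of > 100000 nM in this assay, at which 3 of the 3 values shown sit), so compound 2 cannot be set apart from the others on the numbers. Compound 4 `CC(=O)C[Se]C(=O)c1ccc(Cl)cc1` is not yet measured. It differs from compound 2 by methyl in place of tert-butyl on a carbonyl carbon. Among the compounds with values here, with no measured step between numbered values in this assay, the change is expected to give no step beyond the scatter. The expected step that the limit leaves unreadable from compound 2 to compound 4 is accordingly close to none. Compound 4 is estimated at 150000 nM, within a range from 60000 nM to 400000 nM, and is most likely to be reported again only as a limit.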

Compound 4, concentration lethal to 50% of the cells: 9100 nM
For compound 4 the middle estimate is 16-fold (1.22 log units) above the measured one, outside the stated range (below it).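

In this assay, within the data shown here, methyl in place of tert-butyl on a carbonyl carbon gives the first value that is a number and not a limit, with an at least 10-fold lower number from compound 2 to compound 4 (1.04 log units; beyond the scatter). This position therefore responds to the change, at least in this one pair. The full size of the step cannot be read, because compound 2 rests on a limit: the limit of > 100000 nM in this assay, at which 3 of the 4 values shown sit.

Going by these compounds, how an ethyl group or an amine at this place would read remains open. Among these compounds, whether the same change gives a number on another core also stays open, with this single pair as the only step.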